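The source may hold more compounds than are shown below. What is called first, only, known or untested is meant among the compounds shown, and "the series" means these compounds.

In a functional assay on MCF7 cells (Homo sapiens) for antiproliferative activity, read by MTT assay, with a stated time of 48 h (on this read-out higher numbers stand for weaker inhibition and lower numbers for stronger inhibition), compound 1 `CCOc1cc(-c2ccc3[nH]ccc3c2)cn2c(-c3cc(OC)c(OC)c(OC)c3)nnc12` gives 284 nM and compound 2 `CCOc1cc(-c2ccc3ccn(C)c3c2)cn2c(-c3cc(OC)c(OC)c(OC)c3)nnc12` gives 239 nM, so the two sit within the scatter of each other. Compound 3 `CCOc1cc(-c2ccc3c(ccn3C)c2)cn2c(-c3cc(OC)c(OC)c(OC)c3)nnc12` has the same atoms as compound 2, joined differently: 1-methyl-1H-indol-5-yl in place of 1-methyl-1H-indol-6-yl on an aromatic carbon. The attachment point on the indole moves, while the rest of the molecule stays the same. Among the measured compounds shown here, the only measured step, a 1.2-fold lower number from compound 1 to compound 2 (0.07 log units; within the scatter), replaced 1H-indol-5-yl with 1-methyl-1H-indol-6-yl, so nothing beyond the scatter is expected in this assay. The expected step is a 1.0-fold higher number from compound 2 to compound 3 (0.00 log units; within the scatter). Compound 3 is estimated at 240 nM, with an expected range of 100 nM to 580 nM.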

Compound 3, half-maximal inhibitory concentration: 140 nM
For compound 3 the middle estimate is 1.7-fold (0.23 log units) above the measured one; the measured number falls inside the stated range.
By their numbers in this assay, from the lowest: compounds 3, 2 and 1 (each within the scatter of the next, the first and the last beyond it).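

Among the compounds shown here, with the attachment point held at the 1-methyl-1H-indol-5-yl arrangement's position, compound 1 and compound 3 isolate the methyl on the indole nitrogen, which the earlier step could not do because it changed the attachment point too: this assay shows a 2.0-fold lower number from compound 1 to compound 3 (0.31 log units; beyond the scatter), the only step here beyond the scatter, and a modest one. Moving the attachment point alone, with the methyl kept, gives a 1.7-fold lower number from compound 2 to compound 3 (0.23 log units; within the scatter), so that move cannot be told from the scatter. No measurement here explains the methyl step. As far as these compounds go, an ethyl group or a longer chain on that nitrogen remains open, as does an amine at the end of such a chain.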